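A bromophenoxy isomer of compound 1 awaits measurement

The source may hold more compounds than are shown below. What is called first, only, known or untested is meant among the compounds shown, and "the series" means these compounds.

Compound 1 `NC1=NC2(CCSCC2)N(OCCCOc2ccc(Br)cc2)C(N)=N1` was examined in an assay on isolated protein for inhibition of Dihydrofolate reductase (Homo sapiens), read by spectrophotometry, using NADPH, with stated times of 5 s and 6 min, tested at 5 uM; a lower number here means a weaker effect, a higher number a stronger effect of the compound at the concentration tested. In this assay compound 1 gives > 90%, which is a limit of the assay rather than a number. For the measured compounds named here, compound 2 `NC1=NC2(CCOCC2)N(OCCCOc2ccc(Cl)cc2Cl)C(N)=N1`, the only other measured compound, was run in this assay as well. In this assay compound 2 gives > 90%, again a limit and not a number. Going by the values given here, because both readings sit at the limit of > 90% in this assay, at which 2 of the 2 values shown sit, no step between measured compounds can be sized, and compound 1 can be placed only at that limit, not ranked against compound 2.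

Compound 3 `NC1=NC2(CCSCC2)N(OCCCOc2cccc(Br)c2)C(N)=N1` has not yet been measured in this assay. It differs from compound 1 by 3-bromophenyl in place of 4-bromophenyl on an oxygen on a saturated carbon, with the same atoms joined differently. Among the compounds with values here, the two measured compounds give no step of any kind to draw on, so the change itself is the only guide. The step of a number no higher from compound 1 to compound 3 (the limit leaves the size open) is expected to be none beyond the scatter. For compound 3 in this assay the estimate is 90%, with a range from 72% to 99%, and a further limit reading is the most likely outcome.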

Compound 3, a percentage reported as inhibition, at one concentration (the size of the read-out at that concentration, not a potency): 84.2%
Beside the measured number, compound 3's estimate is 5.8 percentage points above it; the range from low to high includes it.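

Compound 3 is the only compound shown whose reading in this assay is a number rather than a limit, so this position now has one value that is not capped. Placing 3-bromophenyl in place of 4-bromophenyl on an oxygen on a saturated carbon gives a number at least 5.8 percentage points lower from compound 1 to compound 3 (that floor lies within the scatter), so the change leaves a strong effect at the concentration tested but does not show a loss of effect beyond the scatter. The true size of the step stays unknown because the reading for compound 1 is a limit of the assay, and the reading for compound 2 is one as well: the limit of > 90% in this assay, at which 2 of the 3 values shown sit.

The compounds shown leave open whether the reading for 3-bromophenyl would carry over to the core of compound 2, and whether a longer chain between the two oxygens would leave the effect in this assay as it stands. Also open, on these data alone, is what a carboxylic acid or an amine on the phenyl ring in place of the bromine would do to it.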